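The source may hold more compounds than are shown below. What is called first, only, known or untested is meant among the compounds shown, and "the series" means these compounds.

Measured so far in an ADME assay on HEK-293T cells (Homo sapiens) for cytotoxicity, read by MTT assay, with a stated time of 24 h (on this read-out higher numbers stand for lower toxicity in this test and lower numbers for higher toxicity in this test), are two compounds:
- compound 1 `Cc1ccc(-c2nn(-c3ccccc3)cc2-c2nc3ccccc3n2S(=O)(=O)c2cc(C)ccc2C)cc1` gives 82200 nM in this test
- compound 2 `Cc1ccc(-c2nn(-c3ccccc3)cc2-c2nc3ccccc3n2S(=O)(=O)c2ccc(Br)cc2)cc1` gives 159000 nM in this test

Compound 2 stands level with compound 1 on these numbers. Within the data shown here, the one measured step is a 1.9-fold higher number from compound 1 to compound 2 (0.29 log units; within the scatter) and it puts 4-bromophenyl in place of 2,5-dimethylphenyl on a sulfonyl sulfur.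

Compound 3 `Cc1ccc(-c2nn(-c3ccccc3)cc2-c2nc3ccccc3n2S(=O)(=O)c2ccc(C(F)(F)F)cc2)cc1` keeps the rest of compound 2 and changes one group (trifluoromethyl in place of bromo on an aromatic carbon) with trifluoromethyl in place of bromo on an aromatic carbon, para to a large group.

Among the measured compounds shown here, only that one measured step bears on this change, and a single step shows no pattern. It stayed within the scatter, so no step beyond the scatter is expected here in this assay either. The expected size is a 1.1-fold lower number from compound 2 to compound 3 (0.06 log units; within the scatter) by this estimate. Compound 3 is expected at 140000 nM with an estimated range from 65000 nM to 300000 nM in this test.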

Compound 3, half-maximal cytotoxic concentration: 182000 nM
Beside the measured number, compound 3's estimate is 1.3-fold (0.11 log units) below it; the measured number falls inside the stated range.
By their numbers in this assay, from the lowest: compounds 1, 2 and 3 (each within the scatter of the next, the first and the last beyond it).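

In this assay, trifluoromethyl and bromo on this aromatic carbon, para to a large group, read alike: a 1.1-fold higher number from compound 2 to compound 3 (0.06 log units; within the scatter). Among these compounds, four heavy atoms can therefore stand where a single bromine stood with no step beyond the scatter, whereas the wider change of the whole ring on the sulfonyl sulfur gives the first step beyond it, though a modest one: a 2.2-fold higher number from compound 1 to compound 3 (0.35 log units; beyond the scatter). Nothing available explains either step.

On these data alone, whether an amine or a carboxylic acid on this same aromatic carbon would give a similar number remains open. As far as these compounds go, it also remains open which part of the change from 2,5-dimethylphenyl to 4-(trifluoromethyl)phenyl carries the modest step, since that change replaces both methyl groups and adds a trifluoromethyl at once.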